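The source may hold more compounds than are shown below. What is called first, only, known or untested is meant among the compounds shown, and "the series" means these compounds.

Measured in a functional assay on thoracic aorta (Rattus norvegicus, strain Wistar), with a stated time of 15 min; a lower number here means that less compound is needed, a higher number that more compound is needed for the effect:
Compound 1 `CCOc1ccc(F)cc1C(C)NC(=O)N(C)S(=O)(=O)c1ccc(C)cc1`: 7800 nM
Compound 2 `COc1ccc(OC)c(CNC(=O)NS(=O)(=O)c2ccc(C)cc2)c1`: > 300000 nM (a limit)
Compound 3 `COc1ccc(OC)c(CNC(=O)NS(=O)(=O)c2ccccc2)c1`: > 300000 nM (a limit)

In this assay, compound 2 stands at > 300000 nM, which is a limit of the assay and not a number. Compound 4 `COc1ccc(OC)c(CNC(=O)N(C)S(=O)(=O)c2ccc(C)cc2)c1` differs from compound 2 by methyl in place of hydrogen on an amide-type nitrogen. Among the measured compounds shown here, no measured step covers this change. For the measured compounds named here, the one measured step, a step that the two limits leave unreadable from compound 2 to compound 3, concerns hydrogen in place of methyl on an aromatic carbon, so it offers no size to carry over. Going by the values given here, the only guide is compound 1, which also has a methyl on an amide-type nitrogen and gives a measured half-maximal effective concentration of 7800 nM. On that single compound, a step towards less compound needed is expected, though its size is poorly constrained and compound 4 may still reach the limit. The expected step is an at least 10-fold lower number from compound 2 to compound 4 (1.00 log units; beyond the scatter). The estimate for compound 4 is 30000 nM, with an expected range of 6000 nM to 300000 nM.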

Compound 4, half-maximal effective concentration: 20900 nM
For compound 4 the middle estimate is 1.4-fold (0.16 log units) above the measured one, and the stated range covers the measured number.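

In this assay, methyl in place of hydrogen on the amide-type nitrogen, whose other neighbours are the carbonyl carbon and the sulfonyl sulfur, gives an at least 14-fold lower number from compound 2 to compound 4 (1.15 log units; beyond the scatter), the only readable size for a single change among these compounds. Compound 2 stands at > 300000 nM, which is a limit of the assay and not a number. The true size of the step therefore stays unknown and may be larger, because its starting point is that limit: the limit of > 300000 nM in this assay, at which 2 of the 4 values shown sit.

Among the compounds shown here, the one other step, hydrogen in place of methyl on an aromatic carbon, cannot be read, so the role of that aromatic methyl stays open. From the compounds shown here alone, it also remains open whether a propyl chain or a benzyl group on the same nitrogen would lower the number further than methyl does.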